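Adding a Methyl to a Compound at the Assay Limit

The source may hold more compounds than are shown below. What is called first, only, known or untested is meant among the compounds shown, and "the series" means these compounds.

Compound 1 `CC(=O)Nc1ccc(-c2nc3cccc(O)c3s2)cc1C` gives 48200 nM
Compound 2 `CC(=O)Nc1ccc(-c2nc3ccc(O)cc3s2)cc1C` gives 46100 nM
Compound 3 `CC(=O)ON(C(C)=O)c1ccc(-c2nc3ccccc3s2)cc1` gives < 1 nM

All three readings come from a functional assay on MCF7 cells (Homo sapiens) for cytotoxicity; a lower number here means a stronger inhibitor, a higher number a weaker inhibitor. The values of compound 1 and compound 2 lie within the usual scatter of each other. For compound 3 the reading is < 1 nM, which is a limit of the assay and not a number. Compound 3 therefore stands at the limit of < 1 nM in this assay, at which 1 of the 3 values shown sits.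

Compound 4 `CC(=O)ON(C(C)=O)c1ccc(-c2nc3ccccc3s2)cc1C` has not yet been measured. It is compound 3 with methyl in place of hydrogen on an aromatic carbon, ortho to an acetoxy(acetyl)amino group (methyl in place of hydrogen on an aromatic carbon). Compound 1 and compound 2 carry a methyl too, but they differ from compound 3 in more than one place, so neither isolates this change. Among the measured compounds shown here, no measured pair shows what this single swap does in this assay. With so small a change, the expectation is a modest shift, most likely little beyond the scatter, and toward a weaker value if it shows at all. The expected size of the step is a number no lower from compound 3 to compound 4 (the limit leaves the size open). Compound 4 is estimated at 1 nM, with an expected range from 0.1 nM to 30 nM.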

Compound 4, half-maximal inhibitory concentration: 55 nM
For compound 4 the middle estimate is 55-fold (1.74 log units) below the measured one; the measured number lies above the stated range.
By their numbers in this assay, from the lowest: compound 4; then compounds 2 and 1 (each within the scatter of the next). At a limit, below all of these: compound 3.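

In this assay, methyl in place of hydrogen on an aromatic carbon, ortho to an acetoxy(acetyl)amino group, gives an at least 55-fold higher number from compound 3 to compound 4 (1.74 log units; beyond the scatter), so this position does respond to even a one-carbon change. Among the compounds shown here, compound 1 and compound 2 could not show this, as each differs from compound 3 in more than one place, whereas here methyl is the only group that enters and the shift lies well beyond the scatter. The reading for compound 3 is a limit of the assay and not a number, so the step has a lower bound but no exact size: the limit of < 1 nM in this assay, at which 1 of the 4 values shown sits.

The compounds shown leave open whether the shift belongs to methyl in particular or would also follow from another group at this position, such as fluorine, chlorine, ethyl, methoxy or an amine. They also leave open whether methyl has the same effect on a carbon elsewhere in this ring, and how much the acetoxy(acetyl)amino group contributes, which a simple amine or a hydroxyamino group in its place on the core of compound 4 would help to show.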